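Sulfonyl benzimidazoles and a thiophene in place of fluorophenyl

The source may report more compounds than this note shows. Statements on the series, on what has been measured and on what is new or still open speak of the compounds shown alone.

Measured compounds:
- compound 1, `CN(C)S(=O)(=O)c1ccc2nc(-c3ccc(-c4ccccc4F)cc3)[nH]c2c1`, 528 nM
- compound 2, `NS(=O)(=O)c1ccc2nc(-c3ccc(-c4ccccc4F)cc3)[nH]c2c1`, 343 nM
- compound 3, `CS(=O)(=O)c1ccc2nc(-c3ccc(-c4cccc(F)c4)cc3)[nH]c2c1`, 21 nM

In an assay on isolated protein for inhibition of acyl-CoA desaturase 1 (Rattus norvegicus) (on this read-out lower numbers stand for stronger inhibition and higher numbers for weaker inhibition), compound 3 stands lowest of the three; compound 2 lies a good way above it, and compound 1 further still, both gaps beyond the scatter. Going by the values given here, the only single step measured, a 1.5-fold lower number from compound 1 to compound 2 (0.19 log units; within the scatter), concerns the group on the sulfonyl sulfur and stays within the scatter.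

Compound 4, `Cc1ccsc1-c1ccc(-c2nc3ccc(S(C)(=O)=O)cc3[nH]2)cc1`, is not yet measured. It differs from compound 3 in one place: 3-methylthiophen-2-yl in place of 3-fluorophenyl on an aromatic carbon. Among the compounds with values here, no measured step touches this end of the molecule; the one step available, a 1.5-fold lower number from compound 1 to compound 2 (0.19 log units; within the scatter), concerns the sulfonyl end and says nothing about the ring carried para to a large group. The expectation for compound 4 therefore rests on compound 3 alone, and compound 4 is expected at about 35 nM, somewhere between 10 nM and 120 nM. That corresponds to an estimated step of a 1.7-fold higher number from compound 3 to compound 4 (0.22 log units; within the scatter), not expected to exceed the scatter.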

Compound 4, half-maximal inhibitory concentration: 472 nM
Beside the measured number, compound 4's estimate is 13-fold (1.13 log units) below it; measured number above the stated range.
By their numbers in this assay, from the lowest: compound 3; then compounds 2, 4 and 1 (each within the scatter of the next).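

In this assay, replacing 3-fluorophenyl with 3-methylthiophen-2-yl on an aromatic carbon para to a large group gives a 22-fold higher number from compound 3 to compound 4 (1.35 log units; beyond the scatter), so this end of the molecule can shift the read-out well beyond the scatter. Going by these compounds alone, the only earlier single step, a 1.5-fold lower number from compound 1 to compound 2 (0.19 log units; within the scatter), lay at the sulfonyl end and stayed within the scatter, so compound 4 provides the first evidence that the ring at this position matters. Nothing available explains why this exchange weakens inhibition.

The step changes the ring, the methyl and the fluorine together, so the compounds shown cannot assign it to any one of them. From the compounds shown here alone, a plain thiophen-2-yl or a 3-methylphenyl group would separate these parts, while an amine or a carboxylic acid on the ring remains unexplored.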